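The source may report more compounds than this note shows. Statements on the series, on what has been measured and on what is new or still open speak of the compounds shown alone.

Compound 1 `O=c1ccoc2cc(OCc3cn(Cc4cccc(F)c4)nn3)ccc12` anchors the series. In a functional assay on SGC-7901 cells (Homo sapiens) for cytotoxicity, read by MTT assay, with a stated time of 48 h (a lower number here means a stronger inhibitor, a higher number a weaker inhibitor), compound 1 gives only a limit, > 100000 nM. Compound 2 `Cc1ccccc1Cn1cc(COc2ccc3c(=O)ccoc3c2)nn1` likewise returns only a limit in this assay, > 100000 nM. Compound 3 `O=c1ccoc2cc(OCc3cn(Cc4ccc(Cl)cc4)nn3)ccc12` also sits at a limit in this assay, > 100000 nM. The steps a step that the two limits leave unreadable from compound 1 to compound 2, a step that the two limits leave unreadable from compound 1 to compound 3 and a step that the two limits leave unreadable from compound 2 to compound 3 therefore have no readable size, because every value sits at the limit of > 100000 nM in this assay, at which 3 of the 3 values shown sit. Compound 4 `O=c1ccoc2cc(OCc3cn(Cc4cccc(Cl)c4)nn3)ccc12` differs from compound 1 by chloro in place of fluoro on an aromatic carbon. Among the compounds with values here, no measured step bears directly on this change; the changes of the group on the saturated chain carbon bound to an aromatic nitrogen are all unreadable. Compound 4 is expected to remain at the limit as well, with an estimate of 150000 nM in the range 50000 nM to 500000 nM. The step that the limit leaves unreadable from compound 1 to compound 4 is thus expected to be none beyond the scatter.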

Compound 4, half-maximal inhibitory concentration: > 100000 nM
Compound 4 ended at the assay's limit (the forecaster's own chance of this, stated with the estimate: 85%); the middle value is on the limit's open side.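

No new step can be read from compound 4 to compound 1, compound 2 or compound 3, because all four compounds stand at one limit: the limit of > 100000 nM in this assay, at which 4 of the 4 values shown sit.

The compounds shown leave open whether any group on the saturated chain carbon gives a readable value.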